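Chloro for Methoxy: What Compound 4 May Tolerate

A few compounds are considered here, and "the series" means these few. Any claim that something is new, unique, unknown or untested is made for them only; others in the source may bear on it.

Compound 1 `COc1ccc(-c2cs/c(=N\NC(=O)c3ccc(O)cc3)n2-c2ccc(OC)cc2OC)cc1`: < 100000 nM, a limit of the assay.
Compound 2 `O=C(c1ccc(O)cc1)n1nc(-c2c(Cl)cccc2Cl)sc1=S`: 87100 nM.
Compound 3 `Cc1ccc(-c2cs/c(=N\NC(=O)c3ccc(O)cc3)n2-c2c(C)cccc2C)cc1`: < 100000 nM, a limit of the assay.

In a functional assay on MCF7 cells (Homo sapiens) for cytotoxicity, read by sulforhodamine B assay, with a stated time of 48 h (a higher number here means that more compound is tolerated, a lower number that less compound is tolerated), compound 1 stands only at a limit, < 100000 nM, and no number is known for it. Among the measured compounds shown here, compound 2 is the one compound with a measured value there. Two of the three values sit at the limit of < 100000 nM in this assay, at which 2 of the 3 values shown sit, so compound 1 cannot be placed above or below compound 3. Compound 4 `COc1ccc(-n2c(-c3ccc(Cl)cc3)cs/c2=N\NC(=O)c2ccc(O)cc2)c(OC)c1` differs from compound 1 by chloro in place of methoxy on an aromatic carbon. No comparable change has been measured within this set, so the expected step from compound 1 to compound 4 in this assay is none beyond the usual scatter, namely a step that the limit leaves unreadable from compound 1 to compound 4. Compound 4 is therefore estimated at 70000 nM, between 20000 nM and 100000 nM.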

Compound 4, concentration lethal to 50% of the cells: < 100000 nM
Compound 4 was reported as a limit; the forecaster's own chance of this, stated with the estimate: 55%; the middle value is on the limit's open side.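

In this assay compound 4 gives < 100000 nM, a limit of the assay. No step from compound 1 to compound 4 can be read, because both values are limits: the limit of < 100000 nM in this assay, at which 3 of the 4 values shown sit. The compounds shown leave open what chloro in place of methoxy changes in this assay.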